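Methylsulfanyl in place of propargylsulfanyl on the shared core

The compounds below may be only part of what the source reports. "The series", "measured", "known", "first", "only" and "open" are said of these compounds alone.

Compound 1 `CSc1nnc(C)n1N1C(=O)c2ccccc2C1=O` in a functional assay on HepG2 cells (Homo sapiens) for cytotoxicity, read by MTT assay, with a stated time of 48 h (a lower number here means a stronger inhibitor, a higher number a weaker inhibitor), gives > 200000 nM, which is a limit of the assay rather than a number. Compound 2 `C=CCSc1nnc(-c2cc(OC)c(OC)c(OC)c2)n1N1C(=O)c2ccccc2C1=O` gives > 200000 nM, again a limit of the assay. Compound 3 `C#CCSc1nnc(-c2cc(OC)c(OC)c(OC)c2)n1N1C(=O)c2ccccc2C1=O` gives > 200000 nM, also a limit of the assay.

Compound 3 therefore stands nowhere in particular on the numbers shown: it sits at the limit, as do the two other measured values (the limit of > 200000 nM in this assay, at which 3 of the 3 values shown sit). Going by the values given here, the one step among measured compounds, a step that the two limits leave unreadable from compound 2 to compound 3, cannot be read for the same reason.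

Compound 4 `COc1cc(-c2nnc(SC)n2N2C(=O)c3ccccc3C2=O)cc(OC)c1OC` differs from compound 3 by hydrogen in place of ethynyl on a saturated chain carbon bound to a sulfur. Among the compounds with values here, no measured step bears on this change with a readable size, so no direction can be taken from the data. Compound 1, which also carries methylsulfanyl on its core, sits at the limit as well. Compound 4 is expected to stay at the limit in this assay, with the step that the limit leaves unreadable from compound 3 to compound 4 expected to be unreadable. The estimate for compound 4 is 300000 nM, in the range 100000 nM to 1000000 nM, most likely reported only as a limit.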

Compound 4, half-maximal inhibitory concentration: > 200000 nM
Compound 4: a limit, no number; the forecaster's own chance of this, stated with the estimate: 85%; the middle value does not contradict the limit.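

Compound 4 sits at a limit of the assay, as do compound 2 and compound 3, so neither step to compound 4 can be read: the limit of > 200000 nM in this assay, at which 4 of the 4 values shown sit.

The compounds shown leave open whether any change on the shared core would give a readable value in this assay.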